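Hydroxymethyl in place of iodo on the aromatic ring

The compounds below may be only part of what the source reports. "The series", "measured", "known", "first", "only" and "open" are said of these compounds alone.

Compound 3 `O=C(CCCCCc1ccc(I)cc1)N1CCOC1=O` stands at a limit of an assay on HEK293 cells for inhibition of N-acylethanolamine-hydrolyzing acid amidase (Rattus norvegicus), read by LC-MS, with a stated time of 30 min; on this read-out lower numbers stand for stronger inhibition and higher numbers for weaker inhibition: compound 3 gives > 20000 nM, which is a limit and not a number. Compound 1 `O=C(CCCCCc1cccc(I)c1)N1CCOC1=O` gives 3120 nM in this assay. Compound 2 `Nc1cccc(CCCCCC(=O)N2CCOC2=O)c1` gives > 20000 nM, also a limit. The change under study, (hydroxymethyl in place of iodo on an aromatic carbon), leads to compound 4 `O=C(CCCCCc1ccc(CO)cc1)N1CCOC1=O`. Among the compounds with values here, the only measured step, an at least 6.4-fold higher number from compound 1 to compound 2 (0.80 log units; beyond the scatter), likewise removes iodo from the aromatic carbon and moves toward weaker inhibition; the series already rests largely at the limit of > 20000 nM in this assay, at which 2 of the 3 values shown sit. The step expected here is a step that the limit leaves unreadable from compound 3 to compound 4, nothing beyond the scatter. Compound 4 is therefore estimated at 30000 nM, within 10000 nM to 100000 nM, and is expected to return again as a limit.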

Compound 4, half-maximal inhibitory concentration: 190 nM
Compound 4: middle estimate off by 160-fold (2.20 log units), on the high side, and the stated range ends above it.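

In this assay, hydroxymethyl in place of iodo on an aromatic carbon, para to a large group, gives an at least 100-fold lower number from compound 3 to compound 4 (2.02 log units; beyond the scatter), so this position can carry strong inhibition. Losing iodo therefore does not by itself weaken inhibition, although an at least 6.4-fold higher number from compound 1 to compound 2 (0.80 log units; beyond the scatter) ran the other way with amino in place of iodo.

Still open, going by these compounds, is how a carboxylic acid, a methoxymethyl or a longer hydroxyethyl chain would read at this position, and how hydroxymethyl would read where compound 1 carries its iodo. The exact size of the step also stays open, as compound 3 sits at a limit: the limit of > 20000 nM in this assay, at which 2 of the 4 values shown sit.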